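Changing the Amide Cap of Compound 1

The source may report more compounds than this note shows. Statements on the series, on what has been measured and on what is new or still open speak of the compounds shown alone.

Of the compounds shown here, three have been tested in an assay on cells with Cystic fibrosis transmembrane conductance regulator variant F508del (Homo sapiens) as the target, read by fluorescence, with stated times of 24 h and 30 min; a higher number here means that more compound is needed for the effect, a lower number that less compound is needed. Compound 1 `COc1ccccc1C(=O)NCCCNc1nc2cc(C)cc(C)c2cc1C#N` gives 100000 nM in this assay. Compound 3 `COc1ccc(CN2CCc3nc(-c4ccccn4)nc(N4CCN(CCN(C)C)CC4)c3C2)cc1` gives 100000 nM, level with compound 1 at the digits shown, so the two sit together at the top of the set. Compound 2 `COc1ccc(Cl)cc1Cc1cc(-c2sc(NC(=O)C(C)(C)C)nc2C)nn1C(=O)NCCO` gives 3020 nM, a number far lower than that of compound 1 and well beyond the usual scatter. Compound 1 thus stands with compound 3 as the highest of the three numbers and needs much more material than compound 2 to reach the effect.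

Compound 4 `Cc1cc(C)c2cc(C#N)c(NCCCNC(=O)c3ccccn3)nc2c1` is compound 1 with one change: pyridin-2-yl in place of 2-methoxyphenyl on a carbonyl carbon. Among the measured compounds shown here, no measured pair differing in a single place is available, so the step is judged from the structures alone. Since compound 1 gives 100000 nM, the swap of one six-membered aromatic ring for another is expected to leave the number high, with a step that may not exceed the scatter. Compound 4 is estimated at 80000 nM, with a likely range from 20000 nM to 100000 nM. The expected step is a 1.3-fold lower number from compound 1 to compound 4 (0.10 log units; within the scatter).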

Compound 4, half-maximal effective concentration: 100000 nM
For compound 4 the middle estimate is 1.3-fold (0.10 log units) below the measured one; measured number inside the range.
By their numbers in this assay, from the lowest: compound 2; then compounds 1, 3 and 4 (each within the scatter of the next).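

In this assay, among the compounds shown here, the exchange of 2-methoxyphenyl for pyridin-2-yl on a carbonyl carbon gives no change at the digits printed from compound 1 to compound 4 (within the scatter) and is the first step in this set that differs in one place. It shows that, at this position, replacing a six-membered aromatic ring of carbon only with one holding a ring nitrogen leaves the number level and high, so this exchange does not reduce the amount of compound needed. No supporting measurement bears on this result.

With both compounds at the same high number, this pair does not show whether any group on this carbonyl carbon can lower it. A cyclohexyl group, an aminomethyl group or a benzoic acid in this place remains an open test, as does a longer chain on the amide-type nitrogen.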